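Trimming a cyclopentyl to a methyl on a sulfonamide

A few compounds are considered here, and "the series" means these few. Any claim that something is new, unique, unknown or untested is made for them only; others in the source may bear on it.

Measured so far:
compound 1 `CCc1ccc(N(CC(C)C)S(=O)(=O)c2ccc3c(c2)C(=O)CC(C2CCN(S(=O)(=O)C4CCCC4)CC2)O3)cc1` – 4.75
compound 2 `CC(C)CN(c1ccc(N(C)C)cc1)S(=O)(=O)c1ccc2c(c1)C(=O)CC(C1CCOCC1)O2` – 3.6

Of the compounds shown here, two have been measured in a physicochemical assay for lipophilicity, at pH 7.4; on this read-out higher numbers stand for higher lipophilicity and lower numbers for lower lipophilicity. Compound 1 gives 4.75 and stands highest of the two numbers; in this assay compound 2 gives 3.6, a gap that lies beyond the usual scatter. Within the data shown here, the two differ in more than one place, so their values show only that the shared core can sit across a wide span of this read-out.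

Compound 3 `CCc1ccc(N(CC(C)C)S(=O)(=O)c2ccc3c(c2)C(=O)CC(C2CCN(S(C)(=O)=O)CC2)O3)cc1` has not been measured. It keeps everything of compound 1 except one change: methyl in place of cyclopentyl on a sulfonyl sulfur. Four carbon atoms leave the molecule and none of the hydrogen-bond pattern changes. A change of this kind is expected to lower the read-out by a clear margin, well beyond the scatter, so the step of a number 1.35 log units lower from compound 1 to compound 3 (beyond the scatter) is estimated to be downward. Compound 3 is therefore expected to give about 3.4 in this assay, within a range from 2.9 to 3.9.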

Compound 3, distribution coefficient: 3.31
For compound 3 the middle estimate is 0.09 log units above the measured one; the range from low to high includes it.
By their numbers in this assay, from the lowest: compounds 3 and 2 (each within the scatter of the next); then compound 1.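

In this assay, the change from cyclopentylsulfonyl to methylsulfonyl gives a single clean comparison: a number 1.44 log units lower from compound 1 to compound 3 (beyond the scatter). The earlier pair differed in more than one place, so no part of its gap could be assigned to any one group; this step shows that the group on this sulfonyl sulfur can, on its own, move the read-out by a large amount while the rest of compound 1 stays the same. Nothing measured here explains the size of the step.

What the compounds shown leave open is how the read-out behaves between these two groups, for example with an ethyl or isopropyl on the same sulfur. As far as these compounds go, it is also open how a group carrying an amine or a carboxylic acid would behave at this position.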